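The compounds below may be only part of what the source reports. "The series", "measured", "known", "first", "only" and "open" are said of these compounds alone.

Measured so far in an ADME assay on K562 cells (Homo sapiens) for cytotoxicity, read by MTT assay, with a stated time of 5 days; a lower number here means a stronger inhibitor, a higher number a weaker inhibitor:
- compound 1 `COc1ccc(/C=C(\C#N)C(=O)c2cc(OC)c(OC)c(OC)c2)c(F)c1`: > 10000 nM
- compound 2 `COc1ccc(/C=C(\C#N)C(=O)c2cc(OC)c(OC)c(OC)c2)cc1F`: > 10000 nM
- compound 3 `COc1ccc(/C=C(\C#N)C(=O)c2cc(OC)c(OC)c(OC)c2)cc1Br`: > 10000 nM

Compound 1 stands only at a limit of the assay, not at a number. The same holds for compound 2 and for compound 3, so that (the limit of > 10000 nM in this assay, at which 3 of the 3 values shown sit). The steps a step that the two limits leave unreadable from compound 1 to compound 2, a step that the two limits leave unreadable from compound 1 to compound 3 and a step that the two limits leave unreadable from compound 2 to compound 3 are therefore unreadable in size and direction; all three concern the aryl ring on the chain and none touches the chain carbon itself.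

Compound 4 `COc1ccc(/C=C(\F)C(=O)c2cc(OC)c(OC)c(OC)c2)c(F)c1` differs from compound 1 by fluoro in place of cyano on a double-bonded chain carbon bound to a carbonyl carbon and a double-bonded chain carbon. Among the compounds with values here, no measured step bears on this change, and compound 1 gives no number to step from. Compound 4 is therefore expected again at the limit, estimated at 15000 nM with a range of 4000 nM to 60000 nM. The estimated step that the limit leaves unreadable from compound 1 to compound 4 is itself not readable against a limit.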

Compound 4, half-maximal inhibitory concentration: 1190 nM
Estimate against measurement, compound 4: 13-fold (1.10 log units) above; the whole stated range lies above it.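

Within the data shown here, on a double-bonded chain carbon bound to a carbonyl carbon and a double-bonded chain carbon, fluoro in place of cyano gives an at least 8.4-fold lower number from compound 1 to compound 4 (0.92 log units; beyond the scatter) in this assay, the first readable step. This chain carbon therefore brings the read-out off the limit, whereas the aryl ring steps among compound 1, compound 2 and compound 3 cannot be read: the limit of > 10000 nM in this assay, at which 3 of the 4 values shown sit. Compound 1 gives > 10000 nM, which is a limit of the assay.

Going by these compounds, the full size of the step stays open. Also open, on these data alone, is whether chloro, methyl or an amine on this chain carbon would behave as fluoro does, and whether fluoro there gives a number with 3-bromo-4-methoxyphenyl.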